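Dropping the Dihydroxypropyl Carbamoyl from Compound 3

This account rests on a few compounds, and the source may have more. Where it says the series, first, only, none or still open, it means among the compounds named here.

compound 1 `Cn1ncc(Cl)c1-c1cc(C(=O)N[C@@H]2CN[C@H](CCn3cncn3)C[C@H]2c2ccc(Cl)c(Cl)c2)oc1Cl`: 60 nM
compound 2 `Cn1ncc(Cl)c1-c1cc(C(=O)N[C@@H]2CN[C@H](CC(N)=O)C[C@H]2c2ccc(Cl)c(Cl)c2)oc1Cl`: 160 nM
compound 3 `Cn1ncc(Cl)c1-c1cc(C(=O)N[C@@H]2CN[C@H](CC(=O)NCC(O)CO)C[C@H]2c2ccc(Cl)c(Cl)c2)oc1Cl`: 660 nM

In a functional assay on LNCaP cells (Homo sapiens) for antiproliferative activity (on this read-out lower numbers stand for stronger inhibition and higher numbers for weaker inhibition), compound 3 has the highest number of the three, which makes it the weakest so far. Compound 4 `Cn1ncc(Cl)c1-c1cc(C(=O)N[C@@H]2CN[C@H](CCN3CCCC3)C[C@H]2c2ccc(Cl)c(Cl)c2)oc1Cl` carries (pyrrolidin-1-yl)methyl in place of (2,3-dihydroxypropyl)carbamoyl ((pyrrolidin-1-yl)methyl in place of (2,3-dihydroxypropyl)carbamoyl on a saturated chain carbon bound to a saturated ring carbon). Compound 1 is the closest comparison, since it also has a ring-bearing methyl at this place. For the measured compounds named here, two measured steps bear on the change: the large 11-fold higher number from compound 1 to compound 3 (1.04 log units; beyond the scatter) and the modest 4.1-fold higher number from compound 2 to compound 3 (0.62 log units; beyond the scatter). A modest to large move toward a lower number is therefore expected, and the estimated step is a 6.0-fold lower number from compound 3 to compound 4 (0.78 log units; beyond the scatter). For compound 4 the expected value is 110 nM, with an estimated range of 40 nM to 300 nM.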

Compound 4, half-maximal inhibitory concentration: 1920 nM
Estimate against measurement, compound 4: 17-fold (1.24 log units) below, and the stated range ends below it.
By their numbers in this assay, from the lowest: compound 1; then compound 2; then compound 3; then compound 4.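

A ring-bearing methyl at this place does not by itself give a low number: pyrrolidin-1-yl in place of 1H-1,2,4-triazol-1-yl on the chain gives a 32-fold higher number from compound 1 to compound 4 (1.51 log units; beyond the scatter) and so the ring type matters here. The (pyrrolidin-1-yl)methyl group also falls behind both amide-bearing groups, with a 2.9-fold higher number from compound 3 to compound 4 (0.46 log units; beyond the scatter) and a 12-fold higher number from compound 2 to compound 4 (1.08 log units; beyond the scatter) on the same read-out. Nothing available explains this order.

Still open, going by these compounds, is whether the weak result belongs to pyrrolidin-1-yl alone, or would also appear with morpholin-4-yl or 1H-imidazol-1-yl on the same chain.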